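The source may hold more compounds than are shown below. What is called first, only, known or untested is meant among the compounds shown, and "the series" means these compounds.

Working notes on the series. Among the measured compounds shown here, compound 2 `CCO[C@H](CC(=O)O)c1ccc(O[C@@H]2CCc3c2cccc3C(F)(F)F)cc1` gives 330 nM in a functional assay on CHO cells for agonist activity at Free fatty acid receptor 1 (Homo sapiens), read by FLIPR and calcium flux (on this read-out higher numbers stand for an effect only at larger amounts of compound and lower numbers for an effect already at smaller amounts), the highest of the two numbers so far; its nearest neighbour is compound 1 `CCO[C@@H](CC(=O)O)c1ccc(O[C@H]2CCc3c2cccc3C(F)(F)F)cc1`, which gives 19 nM. Compound 3 `CCO[C@H](CC(=O)O)c1ccc(O[C@H]2CCc3c2cccc3C(F)(F)F)cc1` is not yet measured; it differs from compound 2 only in configuration: the two compounds have the same atoms and bonds and differ only in configuration as drawn: 1 of 2 stereo elements differ; a stereocentre at a saturated ring carbon is drawn R in compound 2 and S in compound 3. For the measured compounds named here, the one measured step, a 17-fold higher number from compound 1 to compound 2 (1.24 log units; beyond the scatter), inverted both stereocentres at once, and its size rests on (the fact that compounds 1 and 2 differ only in the configuration as drawn). Inverting the ring centre alone is therefore expected to move the number back part of the way, a step of a 3.3-fold lower number from compound 2 to compound 3 (0.52 log units; beyond the scatter), giving for compound 3 an estimate of 100 nM, within 30 nM to 400 nM.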

Compound 3, half-maximal effective concentration: 2600 nM
For compound 3 the middle estimate is 26-fold (1.41 log units) below the measured one, and the stated range ends below it.
By their numbers in this assay, from the lowest: compound 1; then compound 2; then compound 3.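

Inverting the ring centre alone, with the chain centre drawn R, raises the number in this assay rather than lowering it: a 7.9-fold higher number from compound 2 to compound 3 (0.90 log units; beyond the scatter). Inverting the chain centre alone, with the ring centre drawn S, gives the largest step so far, a 140-fold higher number from compound 1 to compound 3 (2.14 log units; beyond the scatter), so the smaller double inversion, a 17-fold higher number from compound 1 to compound 2 (1.24 log units; beyond the scatter), hides two single steps. Each of these steps comes from configuration alone: the fact that compounds 1 and 3 differ only in the configuration as drawn

Open, on these data alone, is the fourth combination, with the chain centre drawn S and the ring centre drawn R. Also open is whether a nitrile in place of the trifluoromethyl would keep this order.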